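This account rests on a few compounds, and the source may have more. Where it says the series, first, only, none or still open, it means among the compounds named here.

Three compounds share a common core and were tested in an ADME assay (liver) for metabolic stability, with Liver microsome (Rattus norvegicus) as the target, read by LC-MS, using microsomes and NADPH, with stated times of 5 min and 60 min, tested at 4 uM; on this read-out lower numbers stand for a less stable compound and higher numbers for a more stable compound. Compound 1, `CCCC(=O)c1ccc(OCCCCOc2cc(C(=O)O)ccc2OC)c(C)c1O`, gives 1%. Compound 2, `COc1ccc(C(=O)O)cc1OCCCCOc1ccc(C(=O)CC(C)C)c(O)c1C`, gives 5%. These two differ by a single change, (methyl in place of hydrogen on a saturated chain carbon bound to two saturated chain carbons), and the step it made was a number 4 percentage points higher from compound 1 to compound 2 (within the scatter). Compound 3, `CCC(=O)c1ccc(OCCCCOc2ccc(F)c(C(=O)O)c2)c(C)c1O`, gives 35% in this assay, and its values stand beyond the scatter above both compound 1 and compound 2. How the core of compound 3 differs from the core of compound 1 is not broken down here.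

Compound 4, `Cc1c(OCCCCOc2ccc(F)c(C(=O)O)c2)ccc(C(=O)C(C)C)c1O`, is not yet measured. It differs from compound 3 by methyl in place of hydrogen on a saturated chain carbon bound to a carbonyl carbon and a saturated chain carbon. Within the data shown here, this is the same kind of change as the one from compound 1 to compound 2, though the place is not identical: there the carbon sat bound to two saturated chain carbons, here it is bound to a carbonyl carbon and a saturated chain carbon. Among the measured compounds shown here, the only example of this kind of change is the step of a number 4 percentage points higher from compound 1 to compound 2 (within the scatter), which lay within the scatter, so the step expected from compound 3 to compound 4 is likewise small, a number 3 percentage points higher from compound 3 to compound 4 (within the scatter). Compound 4 is therefore estimated to give about 38%, with a likely range from 20% to 56%.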

Compound 4, percent of the compound remaining: 60%
Compound 4: middle estimate off by 22 percentage points, on the low side; the measured number lies above the stated range.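

In this assay, putting methyl in place of hydrogen turned propanoyl into isopropylcarbonyl, and the step was a number 25 percentage points higher from compound 3 to compound 4 (beyond the scatter). The same kind of change therefore did not carry over at one size from one core to the other: the same change on two cores in this assay, a number 4 percentage points higher (within the scatter) from compound 1 to compound 2 and a number 25 percentage points higher (beyond the scatter) from compound 3 to compound 4, 21 percentage points apart, beyond the scatter of two such steps

This does not show why the two steps differ, since the pairs differ both in their cores and in the exact place of the change: a saturated chain carbon bound to two saturated chain carbons in one pair, and one bound to a carbonyl carbon and a saturated chain carbon in the other. Among these compounds, with only two pairs, these two differences cannot be told apart.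

Going by these compounds, it remains open whether the same change would give a small or a large step on a third core. The compounds shown also leave open how a cyclopropyl or a tert-butyl group in place of the isopropyl would read in this assay.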